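The source may report more compounds than this note shows. Statements on the series, on what has been measured and on what is new or still open speak of the compounds shown alone.

Working notes on the shared core of compound 1 `COc1ccc(CSc2nc(O)c(C)c(Cc3c(Cl)cccc3Cl)n2)cc1OC`, compound 2 `COc1ccc(CCSc2nc(Cc3c(Cl)cccc3Cl)c(C)c(=O)[nH]2)cc1` and compound 3 `Cc1c(O)nc(SCc2ccc(O)cc2)nc1Cc1c(Cl)cccc1Cl`, each run in a functional assay on MT4 cells (Homo sapiens) for cytotoxicity, read by MTT assay; a lower number here means that less compound is tolerated, a higher number that more compound is tolerated. Compound 1 gives only a limit of the assay, > 55000 nM. Compound 2 likewise gives only a limit, > 57000 nM. For the measured compounds named here, compound 3 is the one member with a number, 41000 nM. Its standing can only be read against the limit of > 55000 nM in this assay, at which 1 of the 3 values shown sits, and (the limit of > 57000 nM in this assay, at which 1 of the 3 values shown sits). Going by the values given here, no two of these three differ in a single place, so no measured step is available.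

Compound 4 `Cc1c(O)nc(SCc2cccc(Cl)c2)nc1Cc1c(Cl)cccc1Cl` has not yet been measured. It differs from compound 3 by 3-chlorophenyl in place of 4-hydroxyphenyl on a saturated chain carbon bound to a sulfur. Among the compounds with values here, with no measured step to lean on, the step from compound 3 to compound 4 in this assay is expected to be a 1.2-fold higher number from compound 3 to compound 4 (0.09 log units; within the scatter), that is, none beyond the usual scatter. Compound 4 is therefore estimated at 50000 nM, with a range from 25000 nM to 100000 nM, and a fair chance that this assay again reports only a limit.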

Compound 4, half-maximal cytotoxic concentration: > 59000 nM
Compound 4 ended at the assay's limit; the forecaster's own chance of this, stated with the estimate: 50%; middle value at least 1.1-fold (0.07 log units) away from the limit.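

In this assay, this position now has its first measured step, an at least 1.4-fold higher number from compound 3 to compound 4 (0.15 log units; that floor lies within the scatter), with 3-chlorophenyl in place of 4-hydroxyphenyl on a saturated chain carbon bound to a sulfur. Compound 4 gives no number, only a limit of the assay, so this step is a floor and its true size cannot be read: the limit of > 59000 nM in this assay, at which 1 of the 4 values shown sits.

The change removes the hydrogen-bond donor and acceptor counted on 4-hydroxyphenyl, and no lowering of the number comes with it, while a step beyond the scatter is neither shown nor excluded.

The swap alters both the substituent and its ring position, and 4-chlorophenyl or 3-hydroxyphenyl at this place would separate the two. As far as these compounds go, whether an amine or a carboxylic acid on this ring would bring the number down remains open.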